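Shortening the chain from compound 1 to compound 4

A few compounds are considered here, and "the series" means these few. Any claim that something is new, unique, unknown or untested is made for them only; others in the source may bear on it.

In a functional assay on DU-145 cells (Homo sapiens) for inhibition, read by MTT assay, with stated times of 18 h and 4 h (on this read-out lower numbers stand for stronger inhibition and higher numbers for weaker inhibition), compound 1 (`CCCCCCCCOP(=O)(O)OCCSC(=S)N1CCCC1`) gives 47100 nM and compound 3 (`CCCCCCCCOP(=O)(O)OCCSC(=S)N1CCCCCC1`) gives 59100 nM, so both sit at the low end of the numbers shown, with a 1.3-fold higher number from compound 1 to compound 3 (0.10 log units; within the scatter) as their gap. Compound 2 (`CCCCCCCCOP(=O)(O)OCCSC(=S)N1CCN(C)CC1`) gives > 100000 nM, which is a limit of the assay and not a number. Among the compounds with values here, this leaves an at least 2.1-fold higher number from compound 1 to compound 2 (0.32 log units; beyond the scatter) as the only step from compound 1 that is beyond the scatter, while an at least 1.6-fold lower number from compound 2 to compound 3 (0.22 log units; that floor lies within the scatter) is the remaining comparison.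

Compound 4 (`CCCOP(=O)(O)OCCSC(=S)N1CCCC1`) carries hydrogen in place of pentyl on a saturated chain carbon, three bonds along the chain from an oxygen on an unsaturated carbon. Within the data shown here, no measured step touches this chain, since all three change the ring on the thiocarbonyl carbon, so they gauge size only. In this assay a modest rise is expected, resting on the direction of an at least 2.1-fold higher number from compound 1 to compound 2 (0.32 log units; beyond the scatter) and nothing firmer. The expected step is a 2.0-fold higher number from compound 1 to compound 4 (0.30 log units; within the scatter). Compound 4 is estimated at 95000 nM, with an expected range of 45000 nM to 200000 nM.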

Compound 4, half-maximal inhibitory concentration: > 100000 nM
Compound 4: no number, only a limit; the forecaster's own chance of this, stated with the estimate: 50%; at least 1.0-fold (0.02 log units) between middle value and limit.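

In this assay, hydrogen in place of pentyl gives an at least 2.1-fold higher number from compound 1 to compound 4 (0.32 log units; beyond the scatter), so the chain joins the change to 4-methylpiperazin-1-yl as a second place where a step from compound 1 passes the scatter. Compound 4 gives > 100000 nM, which is a limit of the assay and not a number. Only a floor of this step can be read, and compound 4 cannot be ranked against compound 2, which sits at the same limit: the limit of > 100000 nM in this assay, at which 2 of the 4 values shown sit.

Open, from the compounds shown here alone, is whether a chain of intermediate length, or a longer chain than that of compound 1, would move the number in this assay, and what a terminal amine or carboxylic acid on the chain would do. Also open, going by these compounds, is whether the shortened chain behaves alike with azepan-1-yl on the thiocarbonyl carbon.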